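A few compounds are considered here, and "the series" means these few. Any claim that something is new, unique, unknown or untested is made for them only; others in the source may bear on it.

Compound 1 `COc1ccc([C@@H]2[C@H](Oc3ccccc3)C(=O)N2c2cc(OC)c(OC)c(OC)c2)cc1` is the reference point of the series. In a functional assay on MCF7 cells (Homo sapiens) for antiproliferative activity, read by MTT assay, with stated times of 24 h and 72 h (on this read-out lower numbers stand for stronger inhibition and higher numbers for weaker inhibition), compound 1 gives 35000 nM. Compound 3 `COc1cc([C@@H]2[C@H](Oc3ccccc3)C(=O)N2c2cc(OC)c(OC)c(OC)c2)ccc1O` gives 32000 nM and compound 2 `COc1cc(N2C(=O)[C@@H](Oc3ccccc3)[C@H]2c2ccc([N+](=O)[O-])cc2)cc(OC)c1OC` gives 63000 nM; the step of a 1.1-fold lower number from compound 1 to compound 3 (0.04 log units; within the scatter) and the step of a 1.8-fold higher number from compound 1 to compound 2 (0.26 log units; within the scatter) both keep compound 1 in the same band as the other two, so the three measured numbers sit together. Compound 4 `COc1cc(N2C(=O)[C@@H](Oc3ccccc3)[C@H]2c2cc(O)c(OC)c([N+](=O)[O-])c2)cc(OC)c1OC` is not yet measured; it differs from compound 1 by a group of 12 heavy atoms (7 carbon, 1 nitrogen, 4 oxygen; one six-membered aromatic ring of carbon only) in place of a group of 8 heavy atoms (7 carbon, 1 oxygen; one six-membered aromatic ring of carbon only), on a saturated ring carbon. For the measured compounds named here, the steps that bear on it are a 1.8-fold higher number from compound 1 to compound 2 (0.26 log units; within the scatter) (nitro in place of methoxy on an aromatic carbon) and a 1.1-fold lower number from compound 1 to compound 3 (0.04 log units; within the scatter) (4-hydroxy-3-methoxyphenyl in place of 4-methoxyphenyl on a saturated ring carbon), both within the scatter. No step beyond the scatter is therefore expected in this assay; the expected step is a 1.1-fold higher number from compound 1 to compound 4 (0.06 log units; within the scatter). Compound 4 is estimated at 40000 nM, with a range of 15000 nM to 100000 nM.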

Compound 4, half-maximal inhibitory concentration: 69000 nM
Beside the measured number, compound 4's estimate is 1.7-fold (0.24 log units) below it, within the range that was stated.
By their numbers in this assay, from the lowest: compounds 3, 1, 2 and 4 (each within the scatter of the next, the first and the last beyond it).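

In this assay, for the compounds shown here, the group of 12 heavy atoms on the saturated ring carbon gives the first step beyond the scatter, though a modest one: a 2.2-fold higher number from compound 3 to compound 4 (0.33 log units; beyond the scatter). The other two steps stay within the scatter: a 2.0-fold higher number from compound 1 to compound 4 (0.29 log units; within the scatter) and a 1.1-fold higher number from compound 2 to compound 4 (0.04 log units; within the scatter). The data available give no explanation for these steps.

All four aryl groups shown keep the numbers close together. Going by these compounds, whether an amine or a carboxylic acid on this aryl ring would move the number further remains open.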